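A few compounds are considered here, and "the series" means these few. Any claim that something is new, unique, unknown or untested is made for them only; others in the source may bear on it.

In a functional assay on HepG2 cells (Homo sapiens) for cytotoxicity, read by sulforhodamine B assay, with a stated time of 24 h (a lower number here means a stronger inhibitor, a higher number a weaker inhibitor), compound 3 `Cc1ccc(S(=O)(=O)N/N=C2\C(=O)Nc3ccc(S(=O)(=O)N4CCOCC4)cc32)cc1` gives 24700 nM. This lies within the scatter of compound 2 `O=C1Nc2ccc(S(=O)(=O)N3CCOCC3)cc2/C1=N/c1cccc(C(F)(F)F)c1`, which gives 14300 nM, while compound 1 `N#CCC(=O)N/N=C1\C(=O)Nc2ccc(S(=O)(=O)N3CCOCC3)cc21` gives 7530 nM. Compound 4 `N/N=C1\C(=O)Nc2ccc(S(=O)(=O)N3CCOCC3)cc21` differs from compound 3 by one change, hydrogen in place of (4-methylphenyl)sulfonyl on an amine nitrogen. The closest evidence is the change at that same nitrogen, a 3.3-fold higher number from compound 1 to compound 3 (0.52 log units; beyond the scatter), which is modest but beyond the scatter. The other measured change, a 1.9-fold higher number from compound 1 to compound 2 (0.28 log units; within the scatter), stays within the scatter. Neither measurement shows hydrogen at this nitrogen, so the guidance is loose. A modest move to a lower number is expected, a 2.1-fold lower number from compound 3 to compound 4 (0.31 log units; beyond the scatter). For compound 4 the estimated value is 12000 nM, with an expected range of 4500 nM to 30000 nM.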

Compound 4, half-maximal inhibitory concentration: 32400 nM
For compound 4 the middle estimate is 2.7-fold (0.43 log units) below the measured one; measured number above the stated range.
By their numbers in this assay, from the lowest: compounds 1, 2, 3 and 4 (each within the scatter of the next, the first and the last beyond it).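

In this assay the amine nitrogen is now seen carrying hydrogen, and a 1.3-fold higher number from compound 3 to compound 4 (0.12 log units; within the scatter) shows that the loss of the whole (4-methylphenyl)sulfonyl group cannot be told from the scatter. Among these three groups, (cyanomethyl)carbonyl alone stands apart at this nitrogen, with a 4.3-fold higher number from compound 1 to compound 4 (0.63 log units; beyond the scatter) for its replacement by hydrogen, while a 2.3-fold higher number from compound 2 to compound 4 (0.36 log units; beyond the scatter) is a modest step for amino in place of 3-(trifluoromethyl)phenyl on the double-bonded nitrogen. No measurement at hand accounts for these steps.

As far as these compounds go, it remains open whether an acetyl group on this nitrogen, without the nitrile, would keep the lower number of compound 1.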